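A few compounds are considered here, and "the series" means these few. Any claim that something is new, unique, unknown or untested is made for them only; others in the source may bear on it.

Measured compounds:
Compound 1, `COc1cc2cc(Oc3ccc(NC(=O)Nc4cccc(C(F)(F)F)c4)cc3)c(C)nc2cc1OC`, in a functional assay on M14 cells (Homo sapiens) for inhibition, read by sulforhodamine B assay, with a stated time of 48 h (a higher number here means a weaker inhibitor of growth, a lower number a stronger inhibitor of growth), gives 1670 nM.
Compound 2, `COc1cc2cc(Oc3ccc(NC(=O)Nc4ccc(Cl)c(C(F)(F)F)c4)cc3)c(C)nc2cc1OC`, in this assay gives 1250 nM.

Compound 2 has the lowest of the two numbers in this assay, but its nearest neighbour, compound 1, sits only a 1.3-fold lower number from compound 1 to compound 2 (0.13 log units; within the scatter) away, so the two compounds cannot be ranked against each other on these values. Compound 3, `COc1cc2cc(Oc3ccc(NC(=O)Nc4ccc(Cl)c(Cl)c4)cc3)c(C)nc2cc1OC`, has not yet been measured. It differs from compound 2 by chloro in place of trifluoromethyl on an aromatic carbon. For the measured compounds named here, the only measured step, the introduction of a chloro group from compound 1 to compound 2, bears on it just indirectly: it shows that one change on this ring left the number essentially unmoved, at a 1.3-fold lower number from compound 1 to compound 2 (0.13 log units; within the scatter). Going by the values given here, no measured pair shows what replacing the trifluoromethyl group itself does. Compound 3 is therefore expected to land close to compound 2, and the step from compound 2 to compound 3 in this assay is estimated at a 1.4-fold higher number from compound 2 to compound 3 (0.16 log units; within the scatter), with a wide range in either direction. For compound 3 the estimate in this assay is 1800 nM, between 700 nM and 4500 nM.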

Compound 3, concentration for 50% growth inhibition: 2560 nM
The estimate for compound 3 lay 1.4-fold (0.15 log units) below the measured number; the measured number falls inside the stated range.
By their numbers in this assay, from the lowest: compounds 2, 1 and 3 (each within the scatter of the next, the first and the last beyond it).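

In this assay, for the compounds shown here, the place that carries the trifluoromethyl group, ortho to a chloro group, is the first to give a step beyond the scatter: chloro there gives a 2.0-fold higher number from compound 2 to compound 3 (0.31 log units; beyond the scatter), a modest change, whereas the earlier step, a 1.3-fold lower number from compound 1 to compound 2 (0.13 log units; within the scatter), lay within the scatter and concerned the addition of a chloro group, not this exchange. The effect is small and depends on the comparison, since a 1.5-fold higher number from compound 1 to compound 3 (0.19 log units; within the scatter) also lies within the scatter, so compound 3 cannot be separated from compound 1, and only compound 2 and compound 3 can be told apart. Nothing available explains why trifluoromethyl and chloro differ at this place.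

The compounds shown leave open how other groups at this place would compare, such as a methoxy group, a nitrile or an amine, and whether any of them would move the number further than chloro does. On these data alone, it also remains open whether the same exchange gives a step of similar size on another cell line or on a urea with a different core.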